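The source may hold more compounds than are shown below. What is called first, only, known or untested is meant among the compounds shown, and "the series" means these compounds.

In a functional assay on MDA-MB-231 cells (Homo sapiens) for antiproliferative activity, read by MTT assay, with a stated time of 48 h (on this read-out lower numbers stand for stronger inhibition and higher numbers for weaker inhibition), compound 1 `COc1ccc(N(C)c2ccnc(Cl)n2)cc1` gives 2820 nM. With 2-bromoethoxy in place of hydrogen on an aromatic carbon, compound 2 `COc1ccc(N(C)c2ccnc(Cl)n2)cc1OCCBr` gives 6620 nM. For the measured compounds named here, with 3-bromopropoxy in place of that hydrogen, compound 3 `COc1ccc(N(C)c2ccnc(Cl)n2)cc1OCCCBr` gives 1280 nM, the lowest of the three numbers and so the strongest inhibition measured so far.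

Compound 4 `COc1ccc(N(C)c2ccnc(Cl)n2)cc1OCCCCBr` extends the chain once more: bromomethyl in place of bromo on a saturated chain carbon, three bonds along the chain from an oxygen on an aromatic ring. This places bromomethyl in place of bromo on a saturated chain carbon, three bonds along the chain from an oxygen on an aromatic ring, turning 3-bromopropyl into 4-bromobutyl.

Going by the values given here, the closest precedent is the same kind of change made two bonds along the chain, a 5.2-fold lower number from compound 2 to compound 3 (0.71 log units; beyond the scatter). It is a single example, however, and the other steps do not point one way: a 2.3-fold higher number from compound 1 to compound 2 (0.37 log units; beyond the scatter), whereas a 2.2-fold lower number from compound 1 to compound 3 (0.34 log units; beyond the scatter). One lengthening cannot establish a trend, so a repeat of that full drop seems unlikely, and only a small further fall is expected, probably within the scatter.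

The expected change is a 1.2-fold lower number from compound 3 to compound 4 (0.07 log units; within the scatter). The estimate for compound 4 is 1100 nM, with an expected range from 450 nM to 3000 nM.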

Compound 4, half-maximal inhibitory concentration: 992 nM
Compound 4: middle estimate off by 1.1-fold (0.04 log units), on the high side, and the stated range covers the measured number.
By their numbers in this assay, from the lowest: compounds 4 and 3 (each within the scatter of the next); then compound 1; then compound 2.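

In this assay the step from 3-bromopropyl to 4-bromobutyl is a 1.3-fold lower number from compound 3 to compound 4 (0.11 log units; within the scatter) and so, unlike the previous lengthening, gives no change that can be told apart from repeat measurement. The 4-bromobutoxy chain still separates clearly from the shorter and absent chains, with a 6.7-fold lower number from compound 2 to compound 4 (0.82 log units; beyond the scatter) and a 2.8-fold lower number from compound 1 to compound 4 (0.45 log units; beyond the scatter) both showing a real gain, so the effect of chain length appears to level off at compounds 3 and 4 rather than keep growing. Compound 1, which has no chain at all, does not fit a simple rule that longer is better, since its number lies between that of compound 2 and those of the two longer chains, and nothing in the data explains this levelling off.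

Going by these compounds, whether a longer chain than 4-bromobutyl would hold this level, rise or fall is still open. Every chain shown also ends in bromo, so it remains unknown how the same chain would behave with an amine or a carboxylic acid at its end, and therefore whether the bromine matters at all.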